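The compounds below may be only part of what the source reports. "The series", "measured", "known", "first", "only" and "open" are said of these compounds alone.

In a functional assay on MV4-11 cells (Homo sapiens) for antiproliferative activity, read by resazurin assay, with a stated time of 72 h (a higher number here means a weaker inhibitor of growth, a lower number a stronger inhibitor of growth), compound 2 `CN1CCN(c2cccc(Nc3nccc(-c4c[nH]c5ncccc45)n3)c2)CC1` gives 5 nM, while compound 1 `CN1CCN(c2cccc(Nc3nccc(-c4cn(C)c5ncccc45)n3)c2)CC1` gives 24 nM. The change between them is methyl in place of hydrogen on an aromatic nitrogen, and it made a step of a 4.8-fold higher number from compound 2 to compound 1 (0.68 log units; beyond the scatter). Compound 3 `CC(=O)N1CCN(c2ccc(Nc3nccc(-c4c[nH]c5ncccc45)n3)cc2)CC1` reaches a limit of this assay, < 1 nM, so only a bound and not a number is known for it; (the limit of < 1 nM in this assay, at which 1 of the 3 values shown sits). The difference between the core of compound 2 and the core of compound 3 is not broken down here. Compound 4 `CC(=O)N1CCN(c2ccc(Nc3nccc(-c4cn(C)c5ncccc45)n3)cc2)CC1` differs from compound 3 by methyl in place of hydrogen on an aromatic nitrogen, the same kind of change as from compound 2 to compound 1, with the place described in the same words. For compound 4 the step expected is an at least 3.0-fold higher number from compound 3 to compound 4 (0.47 log units; beyond the scatter), a weakening of similar size, because the like change gave a 4.8-fold higher number from compound 2 to compound 1 (0.68 log units; beyond the scatter). Compound 4 is therefore expected to give about 3 nM in this assay, most likely between 0.8 nM and 12 nM.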

Compound 4, concentration for 50% growth inhibition: 74 nM
Estimate against measurement, compound 4: 25-fold (1.39 log units) below; measured number outside the range, above it.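

In this assay compound 3 gives < 1 nM, which is a limit of the assay and not a number. Methyl in place of hydrogen on the aromatic nitrogen also weakens growth inhibition on this second core, with an at least 74-fold higher number from compound 3 to compound 4 (1.86 log units; beyond the scatter), so the direction of the change carries over in these two pairs, though two pairs show nothing about any other core. The size of the change does not carry over: the same change on two cores in this assay, a 4.8-fold higher number (0.68 log units; beyond the scatter) from compound 2 to compound 1 and an at least 74-fold higher number (1.86 log units; beyond the scatter) from compound 3 to compound 4, at least 15-fold (1.18 log units) apart, beyond the scatter of two such steps.

The compounds shown do not break down what separates the two cores, so it stays open which difference between them goes with the larger step. Also open, going by these compounds, is how an ethyl group or a longer chain would behave on that nitrogen in place of the methyl.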